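Swapping the tetrazole group on a long chain

The compounds below may be only part of what the source reports. "The series", "measured", "known", "first", "only" and "open" are said of these compounds alone.

Going by the values given here, compound 1 (`CCCCCNC(=O)NCCCC/C=C\CCCCCSc1nnn[nH]1`) gives 3700 nM in a functional assay on Coronary artery (Bos taurus) (a lower number here means that less compound is needed, a higher number that more compound is needed for the effect), and so holds the higher of the two numbers so far. Compound 2 (`CCCCCCC(=O)N(CCCC/C=C\CCCCCCc1nnn[nH]1)C(C)C`) sits at 1000 nM and the gap between the two lies beyond the scatter. Compound 3 (`CCCCCNC(=O)NCCCC/C=C\CCCCCCc1nsc(=O)[nH]1`) differs from compound 1 by one swap (a group of 7 heavy atoms (3 carbon, 2 nitrogen, 1 oxygen, 1 sulfur; one five-membered aromatic ring with 3 hetero atoms) in place of a group of 6 heavy atoms (1 carbon, 4 nitrogen, 1 sulfur; one five-membered aromatic ring with 4 hetero atoms), on a saturated chain carbon, five bonds along the chain from a double-bonded chain carbon): the (1H-tetrazol-5-yl)sulfanyl group leaves and a five-membered aromatic ring with 3 hetero atoms enters, on a saturated chain carbon. Neither measured compound carries the entering group. In this assay the expected step (a 1.5-fold lower number from compound 1 to compound 3 (0.17 log units; within the scatter)) is none beyond the scatter. Compound 3 is estimated at 2500 nM (range 600 nM to 10000 nM).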

Compound 3, half-maximal effective concentration: 2400 nM
For compound 3 the middle estimate is 1.0-fold (0.02 log units) above the measured one, and the stated range covers the measured number.
By their numbers in this assay, from the lowest: compound 2; then compounds 3 and 1 (each within the scatter of the next).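

Replacing the (1H-tetrazol-5-yl)sulfanyl group with a five-membered aromatic ring with 3 hetero atoms gives in this assay a step of a 1.5-fold lower number from compound 1 to compound 3 (0.19 log units; within the scatter). So the tetrazole and its sulfur are not needed at this place on the chain, since a different ring keeps the number within the usual scatter. No measurement here explains why the two groups read alike. From the compounds shown here alone, whether a carboxylic acid at the same place would also hold the number remains open, as does the effect of a shorter chain carrying the new ring.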